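Methyl position on the benzyl group of compound 2

The source may report more compounds than this note shows. Statements on the series, on what has been measured and on what is new or still open speak of the compounds shown alone.

Measured compounds
compound 1 `COC(=O)[C@H](CCSC)NC(=O)c1ccc(CNCc2c[nH]cn2)cc1-c1ccccc1C` — in a functional assay on NIH3T3 cells (Mus musculus) (a lower number here means that less compound is needed, a higher number that more compound is needed for the effect), compound 1 gives 25 uM.
compound 2 `CSCC[C@H](NC(=O)c1ccc(NCc2cncn2Cc2cccc(C)c2)cc1-c1ccccc1)C(=O)O` — in this assay compound 2 gives only a limit, > 10 uM, not a number.
compound 3 `COC(=O)[C@H](CCSC)NC(=O)c1ccc(NCc2cncn2Cc2cccc(C)c2)cc1-c1ccccc1` — in this assay compound 3 likewise gives only a limit, > 10 uM.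

Compound 2 therefore stands at the edge of what this assay reports; two of the three values shown sit at that same limit (the limit of > 10 uM in this assay, at which 2 of the 3 values shown sit). Among the measured compounds shown here, the only pair that differs in a single place, compound 2 and compound 3, gives a step that the two limits leave unreadable from compound 2 to compound 3, so nothing can be read from it about size or direction. Compound 1 has a different core and no partner that differs from it in one place, so its value stands alone.

Compound 4 `CSCC[C@H](NC(=O)c1ccc(NCc2cncn2Cc2ccccc2C)cc1-c1ccccc1)C(=O)O` differs from compound 2 by 2-methylphenyl in place of 3-methylphenyl on a saturated chain carbon bound to an aromatic nitrogen. For the measured compounds named here, no measured step bears on this change, and the one measured step is unreadable, so there is no footing for expecting a shift beyond the scatter in either direction. Compound 4 is expected to stay near the limit of compound 2, with a chance that only a limit is reported again. The estimate for compound 4 in this assay is 20 uM, with a range from 8 uM to 60 uM. This estimate means a step that the limit leaves unreadable from compound 2 to compound 4, which is expected to be within the scatter.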

Compound 4, concentration for half-maximal effect: > 10 uM
Compound 4: only a limit was reported; the forecaster's own chance of this, stated with the estimate: 70%; the middle value is on the limit's open side.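

In this assay compound 4 gives > 10 uM, a limit and not a number. Compound 2 is also reported only as a limit, so no step can be read between compound 2 and compound 4. On these data alone, whether 2-methylphenyl and 3-methylphenyl on this saturated chain carbon differ at all in this assay remains open.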